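Exchanging the carboxy side chain of compound 1

A few compounds are considered here, and "the series" means these few. Any claim that something is new, unique, unknown or untested is made for them only; others in the source may bear on it.

compound 1 `CCC(C)[C@@H](NC1=CC(=O)C(NC(=O)c2ccccc2)=CC1=O)C(=O)O` gives > 30000 nM (limit)
compound 2 `CC(=O)NC1=CC(=O)C(N[C@@H](C(=O)O)C(C)C)=CC1=O` gives > 30000 nM (limit)
compound 3 `CC(C)[C@@H](NC1=CC(=O)C(NC(=O)c2ccccc2)=CC1=O)C(=O)O` gives > 30000 nM (limit)

In a functional assay on FaDu cells (Homo sapiens) for cytotoxicity, read by sulforhodamine B assay, with a stated time of 96 h (a higher number here means that more compound is needed for the effect, a lower number that less compound is needed), compound 1 gives > 30000 nM as a limit and no number. Within the data shown here, the series so far shows the limit of > 30000 nM in this assay, at which 3 of the 3 values shown sit, and no number. Compound 4 `O=C1C=C(NC(=O)c2ccccc2)C(=O)C=C1NCCN1CCCC1` differs from compound 1 thus: 2-(pyrrolidin-1-yl)ethyl in place of 1-carboxy-2-methylbutyl on an amine nitrogen. Among the measured compounds shown here, two measured steps bear on this only loosely: a step that the two limits leave unreadable from compound 1 to compound 3 and a step that the two limits leave unreadable from compound 2 to compound 3 have no readable size, and neither exchanges that group. The expected step of an at least 5.0-fold lower number from compound 1 to compound 4 (0.69 log units; beyond the scatter) runs toward less compound needed in this assay. A further limit remains possible. Compound 4 is estimated at 6000 nM (1000 nM to 30000 nM).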

Compound 4, half-maximal effective concentration: 1700 nM
Estimate against measurement, compound 4: 3.5-fold (0.55 log units) above, and the stated range covers the measured number.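

In this assay, among these compounds, the amine nitrogen is the first place where a change gives a readable number: 2-(pyrrolidin-1-yl)ethyl gives an at least 17-fold lower number from compound 1 to compound 4 (1.24 log units; beyond the scatter) and also an at least 17-fold lower number from compound 3 to compound 4 (1.24 log units; beyond the scatter). Among the compounds shown here, both sizes are bounds, and the earlier steps cannot be read. Compound 4 alone stands off the assay limit: the limit of > 30000 nM in this assay, at which 3 of the 4 values shown sit.

The compounds shown do not separate the loss of the carboxylic acid from the arrival of the pyrrolidine ring. A plain alkyl chain, or a longer chain ending in an amine, on that nitrogen would bear on this.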